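From a 4-methylphenyl amide to a 3-cyanophenyl amide

The source may report more compounds than this note shows. Statements on the series, on what has been measured and on what is new or still open speak of the compounds shown alone.

Of the compounds shown here, three sharing one core have been measured in a functional assay on A549 cells (Homo sapiens) for inhibition, read by CCK-8 assay, with a stated time of 72 h, tested at 10 uM; on this read-out higher numbers stand for more inhibition of growth at the one concentration tested and lower numbers for less inhibition of growth. Compound 3 `Cc1ccc(NC(=O)C2(C(=O)Nc3ccc(Nc4ncc5cc(C(=O)N(C)C)n(C6CCCC6)c5n4)cc3)CC2)cc1` gives 90.6% and compound 2 `CN(C)C(=O)c1cc2cnc(Nc3ccc(NC(=O)C4(C(=O)Nc5ccc(Br)cc5)CC4)cc3)nc2n1C1CCCC1` gives 90.3%, so the two stand level, while compound 1 `COc1ccc(NC(=O)C2(C(=O)Nc3ccc(Nc4ncc5cc(C(=O)N(C)C)n(C6CCCC6)c5n4)cc3)CC2)cc1` gives 78.5%. Compound 3 thus sits at the top of this small set, together with compound 2.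

Compound 4 `CN(C)C(=O)c1cc2cnc(Nc3ccc(NC(=O)C4(C(=O)Nc5cccc(C#N)c5)CC4)cc3)nc2n1C1CCCC1` has not yet been measured. It differs from compound 3 as follows: 3-cyanophenyl in place of 4-methylphenyl on an amide-type nitrogen. Among the measured compounds shown here, only three steps bear on this change, and all of them exchange one group on an aromatic carbon of the same aryl amide. Bromo in place of methoxy gave a number 11.8 percentage points higher from compound 1 to compound 2 (beyond the scatter), and methyl in place of methoxy gave a number 12.1 percentage points higher from compound 1 to compound 3 (beyond the scatter), both modest. Methyl in place of bromo gave a number 0.3 percentage points higher from compound 2 to compound 3 (within the scatter), within the scatter. For the measured compounds named here, no measured compound carries the 3-cyanophenyl group, so these steps set only a rough scale. Going by them, no step beyond the scatter is expected in this assay, though a slight lean downward is allowed, since compound 3 already stands near the top and compound 1 at 78.5% shows that this aryl group can lower the number. The estimated change is a number 5.6 percentage points lower from compound 3 to compound 4 (within the scatter). Compound 4 is expected at 85%, within an estimated range from 72% to 95%.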

Compound 4, percent growth inhibition at one concentration: 73.6%
Estimate against measurement, compound 4: 11.4 percentage points above; the measured number falls inside the stated range.
By their numbers in this assay, from the lowest: compounds 4 and 1 (each within the scatter of the next); then compounds 2 and 3 (each within the scatter of the next).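

In this assay, the change to 3-cyanophenyl on the amide-type nitrogen gives a number 17 percentage points lower from compound 3 to compound 4 (beyond the scatter) and a number 16.7 percentage points lower from compound 2 to compound 4 (beyond the scatter), so a second aryl group now falls clearly short of the 4-methylphenyl and 4-bromophenyl amides, a gap that previously rested on the 4-methoxyphenyl amide alone. With a number 4.9 percentage points lower from compound 1 to compound 4 (within the scatter), the 3-cyanophenyl and 4-methoxyphenyl amides stand level, and the four compounds form two tiers: compounds 2 and 3 in the upper tier, and compounds 1 and 4 in the lower. This shows that the aryl group on this nitrogen can lower the number in more than one form, but no evidence on hand explains why the four compounds divide in this way.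

Compound 4 is the only compound shown with a nitrile, and its group also carries a different number in its name, so the effects of the nitrile and of its place on the ring cannot be separated. On these data alone, it also remains open how an unsubstituted phenyl, or a phenyl bearing an amine or a carboxylic acid, would compare on this amide-type nitrogen.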